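The source may hold more compounds than are shown below. What is called first, only, known or untested is meant among the compounds shown, and "the series" means these compounds.

Measured in a functional assay on MDA-MB-435 cells (Homo sapiens) for cytotoxicity, read by MTT assay, with a stated time of 72 h; a higher number here means a weaker inhibitor, a lower number a stronger inhibitor:
- Compound 1 `O=C(NCCCNc1c(C(=O)NCc2ccc(F)cc2)nc(Br)c2cccnc12)c1ccccc1`: > 20000 nM (a limit)
- Compound 2 `CNc1c(C(=O)NCc2ccc(F)cc2)nc(Br)c2cccnc12`: > 20000 nM (a limit)

Compound 2 has no number on this scale, only the limit > 20000 nM. Within the data shown here, the series so far rests entirely on (the limit of > 20000 nM in this assay, at which 2 of the 2 values shown sit).

Compound 3 `CNCCCNc1c(C(=O)NCc2ccc(F)cc2)nc(Br)c2cccnc12` differs from compound 2 at one place: 2-(methylamino)ethyl in place of hydrogen on a saturated chain carbon bound to a nitrogen on an aromatic ring. Read one bond further out, methyl gives way to 3-(methylamino)propyl.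

Among the measured compounds shown here, only one measured step concerns this place, where compound 1 carries 2-benzamidoethyl. That step, a step that the two limits leave unreadable from compound 1 to compound 2, has no size that can be carried over. In this assay, at most a modest shift towards stronger inhibition is therefore expected, and compound 3 may well stay at the limit.

Compound 3 is expected at about 15000 nM, with an estimated range from 5000 nM to 40000 nM. This estimate would mean an expected at least 1.3-fold lower number from compound 2 to compound 3 (0.12 log units; that floor lies within the scatter).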

Compound 3, half-maximal inhibitory concentration: 11000 nM
Compound 3: middle estimate off by 1.4-fold (0.13 log units), on the high side; the range from low to high includes it.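

In this assay, compound 3 gives 11000 nM, the only number among the three compounds shown, so this side chain can bring the series onto the measurable scale. Putting 2-(methylamino)ethyl in place of hydrogen on a saturated chain carbon bound to a nitrogen on an aromatic ring gives an at least 1.8-fold lower number from compound 2 to compound 3 (0.25 log units; that floor lies within the scatter), and putting methyl in place of benzoyl on an amine nitrogen gives an at least 1.8-fold lower number from compound 1 to compound 3 (0.25 log units; that floor lies within the scatter). Both steps remain floors rather than sizes, because compound 1 and compound 2 are known only as a limit: the limit of > 20000 nM in this assay, at which 2 of the 3 values shown sit.

Going by these compounds, how large either step really is stays open. So does whether a primary amine or a dimethylamino group at the chain end, or a longer chain, would carry the number beyond the scatter.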